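The source may report more compounds than this note shows. Statements on the series, on what has been measured and on what is new or still open speak of the compounds shown alone.

In a functional assay on MDA-MB-231 cells (Homo sapiens) for antiproliferative activity, read by MTT assay, with a stated time of 48 h (a lower number here means a stronger inhibitor, a higher number a weaker inhibitor), compound 1 `Cc1ccc2nc(Nc3ccnc(Nc4ccc(S(C)(=O)=O)cc4)n3)sc2c1` gives 4440 nM, the lowest of the three numbers shown, although the gap to compound 3 lies within the scatter. Compound 2 `Cc1cnc(Nc2ccc(S(N)(=O)=O)cc2)nc1Nc1nc2ccccc2s1` gives 16800 nM, and compound 3 `NS(=O)(=O)c1ccc(Nc2nccc(Nc3nc4ccccc4s3)n2)cc1` gives 5000 nM. Among the measured compounds shown here, the one comparable pair is a 3.4-fold lower number from compound 2 to compound 3 (0.53 log units; beyond the scatter).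

Compound 4 `COc1ccc2nc(Nc3ccnc(Nc4ccc(S(C)(=O)=O)cc4)n3)sc2c1` differs from compound 1 in one place: methoxy in place of methyl on an aromatic carbon. For the measured compounds named here, no measured pair exchanges a methyl for a methoxy, and the step from compound 2 to compound 3 concerns a different ring and a different exchange, so it offers no direct guide. Going by the values given here, with nothing among the measured compounds speaking for a shift in either direction, the expected outcome for compound 4 in this assay is a number close to that of compound 1, with the expected step from compound 1 to compound 4 being a 1.1-fold lower number from compound 1 to compound 4 (0.02 log units; within the scatter), not beyond the scatter. Compound 4 is therefore estimated at 4200 nM, with a range from 1500 nM to 12000 nM.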

Compound 4, half-maximal inhibitory concentration: 32700 nM
Beside the measured number, compound 4's estimate is 7.8-fold (0.89 log units) below it; measured number outside the range, above it.
By their numbers in this assay, from the lowest: compounds 1 and 3 (each within the scatter of the next); then compounds 2 and 4 (each within the scatter of the next).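

In this assay, exchanging methyl for methoxy on the six-membered aromatic ring of carbon only gives a 7.4-fold higher number from compound 1 to compound 4 (0.87 log units; beyond the scatter), so this place on the core of compound 1 does not tolerate every small group equally. The only earlier step concerned a methyl on a different ring, so this is the first sign among the compounds shown that a change at this place can weaken the antiproliferative read-out beyond the scatter. Nothing available explains why the entering methoxy, with its oxygen and hydrogen-bond acceptor, gives this result.

From the compounds shown here alone, it remains open whether a hydroxyl, an ethyl, a chlorine or a plain hydrogen at this place would move the number in the same direction. Going by these compounds, it is also open whether the same exchange would have a similar effect on compound 3, which carries a sulfonamide.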